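A few compounds are considered here, and "the series" means these few. Any claim that something is new, unique, unknown or untested is made for them only; others in the source may bear on it.

Three compounds that share one core were tested in an assay on membranes from brain for displacement of a labelled ligand from Neuronal acetylcholine receptor; alpha4/beta2 (Rattus norvegicus), with a stated time of 3 h; on this read-out higher numbers stand for weaker inhibition and lower numbers for stronger inhibition. Compound 1 `COc1cc(OC)c(/C=C2\CCCN=C2c2cccnc2)c(OC)c1` gives 60 nM. Going by the values given here, compound 3 `COc1ccc(/C=C2\CCCN=C2c2cccnc2)c(OC)c1` gives 250 nM, and the single change between them amounts to a 4.2-fold higher number from compound 1 to compound 3 (0.62 log units; beyond the scatter). Compound 2 `CCCCOc1ccc(/C=C2\CCCN=C2c2cccnc2)cc1` gives 1960 nM, the highest of the three numbers; compound 3 lies nearest to it and compound 1 furthest away, both gaps being beyond the usual scatter.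

Compound 4 `Clc1ccc(/C=C2\CCCN=C2c2cccnc2)cc1` has not yet been measured. It differs from compound 2 in one place: chloro in place of butoxy on an aromatic carbon. Among the compounds with values here, no measured step swaps one group for another of a different kind at such a place. Within the data shown here, the only measured single change, from compound 1 to compound 3, removes a methoxy altogether and is modest in size, so it offers little guidance on exchanging butoxy for chloro. Compound 2 also stands far above the other two numbers, leaving room for a move in either direction.

With that in mind, compound 4 is expected to give about 600 nM, somewhere between 150 nM and 2500 nM. That expectation corresponds to an estimated step of a 3.3-fold lower number from compound 2 to compound 4 (0.51 log units; beyond the scatter).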

Compound 4, inhibition constant: 970 nM
For compound 4 the middle estimate is 1.6-fold (0.21 log units) below the measured one; measured number inside the range.
By their numbers in this assay, from the lowest: compound 1; then compound 3; then compound 4; then compound 2.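

In this assay the exchange of butoxy for chloro is a 2.0-fold lower number from compound 2 to compound 4 (0.31 log units; beyond the scatter) and, unlike the earlier step, which only removes a methoxy, it replaces one group with a different kind of group on an aromatic carbon. The step stays modest even though butoxy has 5 heavy atoms and 1 hydrogen-bond acceptor, whereas chloro has 1 heavy atom and no hydrogen-bond acceptor, so this large change in group size and acceptor count comes with only a small shift in the number. No measurement available here speaks to the cause of this step.

This one pair cannot separate the effect of losing butoxy from the effect of gaining chloro; plain hydrogen, fluoro, an amine or a carboxylic acid at this place would help to tell them apart. Going by these compounds, it also remains open whether the same exchange would give a similar step on a ring carrying the methoxy groups of compound 1.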